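This account rests on a few compounds, and the source may have more. Where it says the series, first, only, none or still open, it means among the compounds named here.

Compound 3 `CN(C)C(=O)c1cc2cnc(Nc3ccc(NC(=O)C4(C(=O)Nc5ccc(Cl)cc5)CC4)cc3)nc2n1C1CCCC1` is the point of departure. In a functional assay on A549 cells (Homo sapiens) for inhibition, read by CCK-8 assay, with a stated time of 72 h, tested at 10 uM (on this read-out higher numbers stand for more inhibition of growth at the one concentration tested and lower numbers for less inhibition of growth), compound 3 gives 101%. Of the three compounds measured, this is the highest number, but its neighbours sit close. Compound 2 `COC(=O)c1cccc(NC(=O)C2(C(=O)Nc3ccc(Nc4ncc5cc(C(=O)N(C)C)n(C6CCCC6)c5n4)cc3)CC2)c1` gives 91%, and the step of a number 10 percentage points higher from compound 2 to compound 3 (within the scatter) lies within the scatter, so these two cannot be told apart. Compound 1 `Cc1cccc(NC(=O)C2(C(=O)Nc3ccc(Nc4ncc5cc(C(=O)N(C)C)n(C6CCCC6)c5n4)cc3)CC2)c1` gives 86.1%, and the step of a number 14.9 percentage points higher from compound 1 to compound 3 (beyond the scatter) is the only one beyond the scatter. Between the first two, the step of a number 4.9 percentage points higher from compound 1 to compound 2 (within the scatter) again stays within the scatter.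

Compound 4 `CN(C)C(=O)c1cc2cnc(Nc3ccc(NC(=O)C4(C(=O)Nc5ccc(F)cc5)CC4)cc3)nc2n1C1CCCC1` differs from compound 3 in one place: fluoro in place of chloro on an aromatic carbon. Among the measured compounds shown here, none of the measured steps exchanges one halogen for another. The two steps that touch this part of the molecule, from compound 1 and from compound 2 to compound 3, replaced the whole substituted ring and still moved the number only modestly or not beyond the scatter. A swap of a single atom on that ring is therefore expected to change this assay little, if at all beyond the scatter. Compound 3 already lies near complete inhibition, which leaves little room upward, so a step of a number 6 percentage points lower from compound 3 to compound 4 (within the scatter) is estimated. Compound 4 is therefore expected to give about 95%, within a range from 82% to 104%.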

Compound 4, percent growth inhibition at one concentration: 102%
The estimate for compound 4 lay 7 percentage points below the measured number; the measured number falls inside the stated range.
By their numbers in this assay, from the lowest: compounds 1, 2, 3 and 4 (each within the scatter of the next, the first and the last beyond it).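

Among the compounds shown here, exchanging chloro for fluoro on the aromatic ring, para to a large group, is the first change of a single atom at this position, and in this assay it gives a number 1 percentage points higher from compound 3 to compound 4 (within the scatter), so the two halogens cannot be told apart here. Both halogen compounds also stand apart from compound 1, with a number 15.9 percentage points higher from compound 1 to compound 4 (beyond the scatter) alongside a number 14.9 percentage points higher from compound 1 to compound 3 (beyond the scatter), whereas against the ring bearing methoxycarbonyl the step of a number 11 percentage points higher from compound 2 to compound 4 (beyond the scatter) is beyond the scatter and a number 10 percentage points higher from compound 2 to compound 3 (within the scatter) is not, a contrast too slight to separate fluoro from chloro. No measurement available here accounts for why the number holds across this exchange.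

From the compounds shown here alone, whether an amine, a carboxylic acid or a longer chain such as n-butyl in place of the halogen on that ring would keep the number this high remains open. Compound 3 and compound 4 might also separate at lower concentrations, which this assay cannot show with its one tested concentration.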